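The source may report more compounds than this note shows. Statements on the series, on what has been measured and on what is new or still open speak of the compounds shown alone.

Measured compounds:

- compound 1 `CC(=O)OC/C(=C\c1ccc(Cl)cc1Cl)C(=O)c1ccccc1`: 3100 nM
- compound 2 `O=C(OC/C(=C\c1ccc(Cl)cc1Cl)C(=O)c1ccccc1)c1ccccc1`: 3100 nM
- compound 3 `CC(=O)OC/C(=C\c1ccc(Cl)cc1Cl)C(=O)c1ccc(Cl)cc1`: 3200 nM

In a functional assay on HBL-100 cells (Homo sapiens) for inhibition, read by sulforhodamine B assay, with a stated time of 48 h (a higher number here means a weaker inhibitor of growth, a lower number a stronger inhibitor of growth), compound 1 gives 3100 nM and sits level with compound 2, the two together at the lowest figure of the three; compound 3 lies a hair above, still within the scatter. Both recorded steps are flat: no change at the digits printed from compound 1 to compound 2 (within the scatter) and a 1.0-fold higher number from compound 1 to compound 3 (0.01 log units; within the scatter). Within the data shown here, the series so far gives no step that moves this assay beyond its scatter.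

Compound 4 `CC(=O)OC/C(=C/c1ccc(Cl)cc1Cl)C(=O)c1ccccc1` is the next entry. Among the measured compounds shown here, its relation to compound 1 is the two compounds have the same atoms and bonds and differ only in configuration as drawn: 1 of 1 stereo elements differ; a double bond is drawn E in compound 1 and Z in compound 4; in words, the same atoms and bonds, only the double bond drawn Z rather than E. Neither recorded step touches double-bond geometry, so there is no measured precedent for this change; the flat steps to compound 2 and compound 3 only say that the acyl and aromatic edges of the molecule tolerate change. With nothing to anchor a shift, the expected step is no change at the digits printed from compound 1 to compound 4 (within the scatter), i.e. no change beyond the scatter, with a wider range than usual to reflect the absent precedent. Compound 4 is therefore estimated at 3100 nM, between 1200 nM and 8000 nM.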

Compound 4, concentration for 50% growth inhibition: 23000 nM
Compound 4: middle estimate off by 7.4-fold (0.87 log units), on the low side; the whole stated range lies below it.
By their numbers in this assay, from the lowest: compounds 1, 2 and 3 (each within the scatter of the next); then compound 4.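

In this assay, among these compounds, double-bond geometry is the first change to move the number beyond the scatter (a 7.4-fold higher number from compound 1 to compound 4 (0.87 log units; beyond the scatter)), whereas the changes at the acyl group and on the aromatic ring stayed flat. The double bond is therefore the one position shown so far where the series responds, with the E compound 1 giving the lower number of this pair. The step can be assigned to the double bond alone, and the ground for that is: the fact that compounds 1 and 4 differ only in the configuration as drawn

The compounds shown leave open whether the Z geometry carries the same penalty with the benzoate ester of compound 2 or the added chloro group of compound 3. They also leave open whether the E series keeps its level when an amine or a carboxylic acid replaces the acetate ester.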